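The source may report more compounds than this note shows. Statements on the series, on what has been measured and on what is new or still open speak of the compounds shown alone.

Working notes on the hydantoin sulfonamide series.

Of the compounds shown here, three have been measured in a functional assay on SK-MEL-2 cells (Homo sapiens) for cytotoxicity; a lower number here means a stronger inhibitor, a higher number a weaker inhibitor. Compound 1, `O=C1NC(c2ccc(Br)cc2)CN1S(=O)(=O)c1ccc2c(c1)CCC2`, gives 32600 nM. Compound 2, `Cc1ccc(C2CN(S(=O)(=O)c3ccccc3)C(=O)N2)cc1`, returns only a limit of the assay, > 316000 nM, and no number. Compound 3, `Cc1ccc(C2CN(S(=O)(=O)c3ccc(Cl)cc3)C(=O)N2)cc1`, gives 123000 nM, the higher of the two numbers obtained; the nearest measured neighbour is compound 1 with its lower number. For the measured compounds named here, the single measured step, an at least 2.5-fold lower number from compound 2 to compound 3 (0.40 log units; beyond the scatter), lies on the sulfonyl-bearing ring; the limit for compound 2 is noted as the limit of > 316000 nM in this assay, at which 1 of the 3 values shown sits.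

Compound 4, `O=C1NC(c2ccccc2)CN1S(=O)(=O)c1ccc(Cl)cc1`, differs from compound 3 as follows: hydrogen in place of methyl on an aromatic carbon. Going by the values given here, this change sits on the other ring, not the one altered from compound 2 to compound 3, so no measured step covers it directly. Among the compounds with values here, with no bearing precedent, the expected step is a 1.1-fold higher number from compound 3 to compound 4 (0.02 log units; within the scatter), that is, none beyond the scatter. Compound 4 is therefore estimated at 130000 nM, within 50000 nM to 320000 nM, with some chance that only a limit is returned.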

Compound 4, half-maximal inhibitory concentration: 1430 nM
Beside the measured number, compound 4's estimate is 91-fold (1.96 log units) above it; the measured number lies below the stated range.
By their numbers in this assay, from the lowest: compound 4; then compound 1; then compound 3. At a limit, above all of these: compound 2.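

In this assay, hydrogen in place of methyl on the aromatic carbon para to a large group gives an 86-fold lower number from compound 3 to compound 4 (1.93 log units; beyond the scatter). For the compounds shown here, until now, the only measured step lay on the sulfonyl-bearing ring; this first step on the other ring shows that the loss of a single carbon at this one position is enough to move the number far beyond the scatter. Going by these compounds alone, nothing measured so far offers a reason for a step of this size.

On these data alone, the step has been read only with the chloro group present on the sulfonyl-bearing ring, so whether 4-methylphenyl to phenyl has the same effect without it remains open. Also open, as far as these compounds go, is how a fluoro, a hydroxyl or an amine at this position would compare with the hydrogen of compound 4.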